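A Bromine Added to the Core of Compound 2

This account rests on a few compounds, and the source may have more. Where it says the series, first, only, none or still open, it means among the compounds named here.

Compound 2 `Cc1noc(NS(=O)(=O)c2ccc(NC(=O)c3cc4ccccc4oc3=O)cc2)c1C` joins the shared core through an amide to an aryl group bearing a sulfonamide. For the measured compounds named here, in a functional assay on PANC-1 cells (Homo sapiens) for antiproliferative activity, read by fluorescence and resazurin assay, with a stated time of 48 h (on this read-out higher numbers stand for weaker inhibition and lower numbers for stronger inhibition), compound 2 gives 19900 nM, the highest of the three numbers measured so far. Compound 1 `O=C(N/N=C/c1ccncc1)c1cc2ccccc2oc1=O`, a hydrazone of the same core, gives 9750 nM in this assay, and compound 3 `O=C(N/N=C/c1cc2ccccc2nc1Cl)c1cc2cc(Br)ccc2oc1=O`, which carries a bromine on its core among other differences, gives 5450 nM; both gaps to compound 2 lie beyond the usual scatter. Going by the values given here, compounds 1 and 3 differ from each other in more than one place, so only their two values can be compared and no single step is read from them.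

The new compound 4 `Cc1noc(NS(=O)(=O)c2ccc(NC(=O)c3cc4cc(Br)ccc4oc3=O)cc2)c1C` differs from compound 2 in one place only: bromo in place of hydrogen on an aromatic carbon. Among the compounds with values here, no measured pair differs by exactly this change, so the size of the step is open. Within the data shown here, compound 3, the one measured compound with a bromo group on its core, shows the lowest number, but it differs elsewhere too, so this is only a hint. For compound 4 a modest move toward a lower number is expected, estimated as a step of a 2.0-fold lower number from compound 2 to compound 4 (0.30 log units; within the scatter). Compound 4 is thus expected to give about 10000 nM, within a range from 3500 nM to 30000 nM.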

Compound 4, half-maximal inhibitory concentration: 28700 nM
Beside the measured number, compound 4's estimate is 2.9-fold (0.46 log units) below it, within the range that was stated.
By their numbers in this assay, from the lowest: compounds 3 and 1 (each within the scatter of the next); then compounds 2 and 4 (each within the scatter of the next).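

In this assay, for the compounds shown here, bromo in place of hydrogen on this aromatic carbon gives a 1.4-fold higher number from compound 2 to compound 4 (0.16 log units; within the scatter) and, as the first step here that isolates a single change, it lies within the usual scatter. Going by these compounds alone, on this amide-linked, sulfonamide-bearing compound, therefore, adding the bromine leaves no readable difference in antiproliferative activity, and the hint taken from compound 3 finds no support in this pair, while compound 3 differs from the others in more than one place and its number cannot be credited to its bromine alone. No measurement shown here offers an explanation for this result.

On these data alone, whether an amine or a methoxy group in place of hydrogen on this same aromatic carbon would give a step beyond the scatter remains open. Also open, as far as these compounds go, is whether bromo in place of hydrogen would give a similar result on the hydrazone compound 1, since a single pair cannot show whether this outcome holds beyond compound 2 and compound 4.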